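The compounds below may be only part of what the source reports. "The series", "measured", "known", "first", "only" and "open" are said of these compounds alone.

Compound 2 `c1ccc(COc2nc3ccccc3s2)cc1` in a functional assay on the whole organism with Mus musculus as the target, in the writhing test, at a dose of 100 mg/kg by the intraperitoneal route (on this read-out lower numbers stand for less inhibition and higher numbers for more inhibition at the one dose given (going by the name of the read-out)), gives 51.9%, level with compound 1 `Brc1ccccc1COc1nc2ccccc2s1`, which in this assay gives 51.9%. Compound 3 `Brc1cccc(COc2nc3ccccc3s2)c1` differs from compound 2 by bromo in place of hydrogen on an aromatic carbon. Among the compounds with values here, the one measured step that bears on this change, no change at the digits printed from compound 1 to compound 2 (within the scatter), removed a bromo from an aromatic carbon without any shift beyond the scatter. The change that turns compound 2 into compound 3 is therefore expected to leave the read-out about where compound 2 stands. Compound 3 is estimated at 52%, with a range from 40% to 64%, so the expected step of a number 0.1 percentage points higher from compound 2 to compound 3 (within the scatter) lies within the scatter.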

Compound 3, a percentage reported as inhibition, in the whole organism at one dose (the size of the read-out at that dose, not a potency): 51.9%
Compound 3: middle estimate off by 0.1 percentage points, on the high side; low and high end bracket the measured number.
By their numbers in this assay, from the lowest: compounds 1, 2 and 3 (each within the scatter of the next).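

In this assay, there is no change at the digits printed from compound 2 to compound 3 (within the scatter) when bromo enters on an aromatic carbon meta to a large group. The earlier step covered only the bromo placement of compound 1, whereas this one shows that a second placement on the same ring also brings no shift beyond the scatter at this single dose. No measured evidence explains this flat result. From the compounds shown here alone, whether a different group here, such as an amine or a carboxylic acid, would move the read-out remains open. A single dose also leaves open whether these compounds differ at other doses.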